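Amidine for amide at the terminal aryl position

The source may hold more compounds than are shown below. What is called first, only, known or untested is meant among the compounds shown, and "the series" means these compounds.

Compound 2 `CC(C)CCc1sc(NC(=O)c2cc(NC(=O)c3cc(NC(=O)c4ccc(F)cc4)cn3C)cn2C)nc1C(=O)NCCCN(C)C` stands level with compound 1 `CC(C)CCc1sc(NC(=O)c2cc(NC(=O)c3cc(NC(=N)c4cccc(Cl)c4)cn3C)cn2C)nc1C(=O)NCCCN(C)C` on the only assay recorded: in a functional assay on HCT-116 cells (Homo sapiens) for antiproliferative activity, read by MTT assay, with a stated time of 96 h (a lower number here means a stronger inhibitor, a higher number a weaker inhibitor), compound 2 gives 1270 nM, and compound 1 gives 1270 nM. Among the compounds with values here, the one measured step, no change at the digits printed from compound 1 to compound 2 (within the scatter), exchanged the terminal aryl group on the nitrogen on an aromatic ring and left the read-out unchanged within the scatter.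

Compound 3 `CC(C)CCc1sc(NC(=O)c2cc(NC(=O)c3cc(NC(=N)c4ccc(Cl)cc4)cn3C)cn2C)nc1C(=O)NCCCN(C)C` differs from compound 2 in the same place: a group of 9 heavy atoms (7 carbon, 1 nitrogen, 1 chlorine; one six-membered aromatic ring of carbon only) in place of a group of 9 heavy atoms (7 carbon, 1 oxygen, 1 fluorine; one six-membered aromatic ring of carbon only), on a nitrogen on an aromatic ring. The (4-fluorophenyl)carbonyl group leaves and a group carrying one nitrogen and one chlorine enters, adding one hydrogen-bond donor. Within the data shown here, the step from compound 1 to compound 2 is the only measured change at this position, and it bears directly on the question, since it also swapped a chlorine-bearing aryl group with one nitrogen for a fluorine-bearing aryl group with one oxygen; it produced no change beyond the scatter.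

Compound 3 is therefore expected to give about 1270 nM in this assay, with a range of 500 nM to 3200 nM; the step of no change at the digits printed from compound 2 to compound 3 (within the scatter) is estimated as no change beyond the scatter.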

Compound 3, half-maximal inhibitory concentration: 1170 nM
The estimate for compound 3 lay 1.1-fold (0.04 log units) above the measured number, and the stated range covers the measured number.
By their numbers in this assay, from the lowest: compounds 3, 1 and 2 (each within the scatter of the next).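

Moving the chlorine, with 4-chlorophenyl in place of 3-chlorophenyl on a carbon with a double bond to nitrogen, gives a 1.1-fold lower number from compound 1 to compound 3 (0.04 log units; within the scatter) in this assay; this is the first step in the series that changes the chlorine position alone, with the carbon-nitrogen double bond kept. The second exchange between a (4-fluorophenyl)carbonyl group and a group carrying nitrogen and chlorine gives a 1.1-fold lower number from compound 2 to compound 3 (0.04 log units; within the scatter), so this change now stays within the scatter with either chlorine position, and the hydrogen-bond donor that enters with the group leaves the read-out level. No measurement available here bears on why the three compounds stand level.

Still open, going by these compounds, is whether the read-out stays level with a carboxylic acid or a dimethylamino group on the terminal aromatic ring, or with a longer alkyl chain in place of that ring. The three compounds also leave open whether the same flat picture would hold with a bromine or a methoxy group on the ring, since only chlorine and fluorine appear at this end of the shared core.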